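Lengthening the chlorinated chain on compound 2

A few compounds are considered here, and "the series" means these few. Any claim that something is new, unique, unknown or untested is made for them only; others in the source may bear on it.

Of the compounds shown here, two sharing one core have been tested in a functional assay on NCI-H460 cells (Homo sapiens) for antiproliferative activity, read by MTT assay, with a stated time of 48 h; on this read-out lower numbers stand for stronger inhibition and higher numbers for weaker inhibition. Compound 1, `COc1ccccc1C(=O)Nc1nnc(SCC(=O)Nc2ccc(Cl)cn2)s1`, reached only the assay's limit, giving > 80000 nM. Compound 2, `O=C(CSc1nnc(NC(=O)CCl)s1)Nc1ccc(Cl)cn1`, gives 5700 nM in this assay. Within the data shown here, the one measured step runs an at least 14-fold lower number from compound 1 to compound 2 (1.14 log units; beyond the scatter); since compound 1 sits at the limit, the true size of that step is not known beyond (the limit of > 80000 nM in this assay, at which 1 of the 2 values shown sits). Among the measured compounds shown here, compound 2 therefore holds the only actual number in the set, and the sole limit belongs to compound 1.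

Compound 3, `O=C(CSc1nnc(NC(=O)CCCCl)s1)Nc1ccc(Cl)cn1`, changes compound 2 by 2-chloroethyl in place of chloro on a saturated chain carbon bound to a carbonyl carbon. For the measured compounds named here, no measured step touches this position: the only step seen swaps one whole group on the carbonyl carbon for another, whereas here the chain beyond the carbonyl is simply extended. That step gives no direction for the present change, so the expectation rests on compound 2 alone, with wide uncertainty. Compound 3 is expected to show a 3.5-fold higher number from compound 2 to compound 3 (0.55 log units; beyond the scatter) in this assay, most likely a somewhat weaker result. The estimate for compound 3 is 20000 nM, with a plausible range from 5000 nM to 80000 nM.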

Compound 3, half-maximal inhibitory concentration: 55200 nM
Compound 3: the middle estimate sits 2.8-fold (0.44 log units) below what was measured; the range from low to high includes it.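

The position on the saturated chain carbon bound to a carbonyl carbon proves sensitive to chain length: in this assay, replacing chloro with 2-chloroethyl gives a 9.7-fold higher number from compound 2 to compound 3 (0.99 log units; beyond the scatter). The earlier step swapped a whole 2-methoxyphenyl group for chloromethyl, whereas this change keeps a chlorinated chain on the carbonyl carbon and alters only its length, so it shows that, within these two compounds, the longer chain gives the weaker result. The comparison with compound 1 reads an at least 1.4-fold lower number from compound 1 to compound 3 (0.16 log units; that floor lies within the scatter), which does not separate the two compounds, and its true size stays unknown, as compound 1 gives only a limit of the assay: the limit of > 80000 nM in this assay, at which 1 of the 3 values shown sits.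

Still open, from the compounds shown here alone, is whether the weaker result of compound 3 depends on chain length alone or also on the chlorine the chain carries. A plain propyl chain on the carbonyl carbon would help separate those two possibilities, and an intermediate chain, such as 2-chloroethyl on the carbonyl carbon, would show whether the number rises gradually or abruptly as the chain grows.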